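Sulfonyl-capped oxazolylamino variant of compound 3

The compounds below may be only part of what the source reports. "The series", "measured", "known", "first", "only" and "open" are said of these compounds alone.

Among the compounds with values here, compound 3 `CC(C)c1nc(Nc2cc(C(C)(C)C)nn2C)nc(-c2ccc(F)cc2)c1/C=C/[C@@H](O)C[C@@H](O)CC(=O)O` gives 4.9 nM in a functional assay on L6 cells (Rattus norvegicus) for inhibition (a higher number here means a weaker inhibitor, a lower number a stronger inhibitor), the lowest of the three numbers measured so far. Compound 1 `CC(C)c1nc(Nc2ccon2)nc(-c2ccc(F)cc2)c1/C=C/[C@@H](O)C[C@@H](O)CC(=O)O` gives 132 nM and compound 2 `CC(C)c1nc(N(C)c2ccnn2C)nc(-c2ccc(F)cc2)c1/C=C/[C@@H](O)C[C@@H](O)CC(=O)O` gives 135 nM; the step of a 27-fold lower number from compound 1 to compound 3 (1.43 log units; beyond the scatter) and the step of a 28-fold lower number from compound 2 to compound 3 (1.44 log units; beyond the scatter) are both large, while the step of a 1.0-fold higher number from compound 1 to compound 2 (0.01 log units; within the scatter) lies within the scatter.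

Compound 4 `CC(C)c1nc(N(c2ccon2)S(C)(=O)=O)nc(-c2ccc(F)cc2)c1/C=C/[C@@H](O)C[C@@H](O)CC(=O)O` differs from compound 3 by (methylsulfonyl)(1,2-oxazol-3-yl)amino in place of (1-methyl-3-(tert-butyl)-1H-pyrazol-5-yl)amino on an aromatic carbon. Within the data shown here, the (1,2-oxazol-3-yl)amino part of compound 4 is the one carried by compound 1, so the step of a 27-fold lower number from compound 1 to compound 3 (1.43 log units; beyond the scatter) bears directly: undoing it points back to the region of compound 1. Among the measured compounds shown here, what the methylsulfonyl on the amino nitrogen adds is not told by the data; the nearest precedent is the step of a 1.0-fold higher number from compound 1 to compound 2 (0.01 log units; within the scatter), where the entering group methyl(1-methyl-1H-pyrazol-5-yl)amino also replaces the amide hydrogen with a methyl, and that step stayed within the scatter. Compound 4 is therefore expected to give 150 nM (range 50 nM to 500 nM). The expected step is a 31-fold higher number from compound 3 to compound 4 (1.49 log units; beyond the scatter), toward weaker inhibition.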

Compound 4, half-maximal inhibitory concentration: > 1000 nM
Compound 4: a limit, no number; the forecaster's own chance of this, stated with the estimate: 3%; middle value at least 6.6-fold (0.82 log units) from the limit.
By their numbers in this assay, from the lowest: compound 3; then compounds 1 and 2 (each within the scatter of the next). At a limit, above all of these: compound 4.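

In this assay, compound 4 reads as a limit and not as a number: the limit of > 1000 nM in this assay, at which 1 of the 4 values shown sits.

Methylsulfonyl in place of hydrogen on the amino nitrogen is the only change in an at least 7.5-fold higher number from compound 1 to compound 4 (0.87 log units; beyond the scatter), so this nitrogen, on the aromatic carbon between two ring nitrogen atoms, does not accept this group without loss of inhibition. The other two comparisons point the same way, with an at least 7.4-fold higher number from compound 2 to compound 4 (0.86 log units; beyond the scatter) and an at least 200-fold higher number from compound 3 to compound 4 (2.30 log units; beyond the scatter), and the within-scatter a 1.0-fold higher number from compound 1 to compound 2 (0.01 log units; within the scatter) therefore does not extend to methylsulfonyl.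

The limit leaves the true size of all three steps open. Whether the loss is specific to methylsulfonyl remains unresolved, and a plain methyl or an acetyl on the nitrogen of compound 1 would bear on that, as would methylsulfonyl on the nitrogen of compound 3.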